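This account rests on a few compounds, and the source may have more. Where it says the series, first, only, none or still open, it means among the compounds named here.

Measured compounds:
Compound 1, `O=C1NC(=S)S/C1=C\N1N=C(c2ccc(Cl)cc2)CC1c1ccc(Cl)cc1`, gives in a functional assay on HL-60 cells (Homo sapiens) for antiproliferative activity, read by MTT assay, with a stated time of 72 h; a higher number here means a weaker inhibitor, a lower number a stronger inhibitor > 10000 nM, a limit of the assay.
Compound 2, `CC(=O)Oc1ccc(N2C(=O)/C(=C/N3N=C(c4ccc5ccccc5c4)CC3c3ccc(Cl)cc3)SC2=S)cc1`, gives in this assay 1800 nM.
Compound 3, `COc1ccc(C2CC(c3ccc4ccccc4c3)=NN2/C=C2\SC(=S)N(c3ccc(OC(C)=O)cc3)C2=O)cc1`, gives in this assay > 10000 nM, also a limit.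

Going by the values given here, compound 2 thus holds the only real number in this assay; the other two results are limits. Among the compounds with values here, the single measured step, an at least 5.5-fold higher number from compound 2 to compound 3 (0.74 log units; beyond the scatter), concerns a methoxy in place of chloro and not the ring nitrogen. Compound 4, `O=C1NC(=S)S/C1=C\N1N=C(c2ccc3ccccc3c2)CC1c1ccc(Cl)cc1`, differs from compound 2 by hydrogen in place of 4-acetoxyphenyl on an amide-type nitrogen in a ring. Within the data shown here, no measured step covers this change, so its size is uncertain. Compound 1, which also carries hydrogen on that nitrogen, sits at a limit. Compound 4 is therefore expected to give a higher number, a 3.3-fold higher number from compound 2 to compound 4 (0.52 log units; beyond the scatter), with an estimate of 6000 nM between 1500 nM and 20000 nM, because of the limit of > 10000 nM in this assay, at which 2 of the 3 values shown sit.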

Compound 4, half-maximal inhibitory concentration: 400 nM
Estimate against measurement, compound 4: 15-fold (1.18 log units) above, and the stated range ends above it.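

In this assay, the 4-acetoxyphenyl group on the amide-type nitrogen proves unnecessary for activity, as hydrogen in its place gives a 4.5-fold lower number from compound 2 to compound 4 (0.65 log units; beyond the scatter). Hydrogen on that nitrogen does not suffice alone, however: with it in place, naphthalen-2-yl in place of 4-chlorophenyl on the carbon with a double bond to nitrogen gives an at least 25-fold lower number from compound 1 to compound 4 (1.39 log units; beyond the scatter). The true size of that second step remains unknown, as it starts from a limit: the limit of > 10000 nM in this assay, at which 2 of the 4 values shown sit.

The compounds shown leave open whether methyl or an acetic acid chain on that nitrogen would match hydrogen. They also leave open how methoxy in place of chloro acts when that nitrogen carries hydrogen.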